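Working notes: lengthening the linker chain of compound 1

The source may hold more compounds than are shown below. What is called first, only, known or untested is meant among the compounds shown, and "the series" means these compounds.

Compound 1 `CC(C)(C)[Si](OCc1ccc(=O)[nH]n1)(c1ccccc1)c1ccccc1`: 62600 nM
Compound 2 `CC(C)(C)[Si](OCc1ccc(=O)n(Cc2ccccc2)n1)(c1ccccc1)c1ccccc1`: limit, > 100000 nM
Compound 3 `O=c1ccc(CO)nn1Cc1ccccc1`: limit, > 100000 nM

For the measured compounds named here, in a functional assay on aorta (Rattus norvegicus) (on this read-out lower numbers stand for stronger inhibition and higher numbers for weaker inhibition), compound 1 gives 62600 nM, the only real number among the three entries. Compound 2 reaches only the limit of the assay, > 100000 nM. Compound 3 likewise stops at the limit, > 100000 nM. Going by the values given here, the single measured step, an at least 1.5-fold higher number from compound 1 to compound 2 (0.20 log units; that floor lies within the scatter), concerns a benzyl on an aromatic nitrogen and not the chain; the limit of > 100000 nM in this assay, at which 2 of the 3 values shown sit, marks where two of the three entries sit. Compound 4 `CC(C)(C)[Si](OCCc1ccc(=O)[nH]n1)(c1ccccc1)c1ccccc1` differs from compound 1 by a group of 8 heavy atoms (5 carbon, 2 nitrogen, 1 oxygen; one six-membered aromatic ring with 2 hetero atoms) in place of a group of 7 heavy atoms (4 carbon, 2 nitrogen, 1 oxygen; one six-membered aromatic ring with 2 hetero atoms), on a saturated chain carbon bound to an oxygen. Among the compounds with values here, no measured step touches that chain, so no step beyond the scatter is expected in this assay, while a limit remains a real possibility. Compound 4 is therefore estimated at 70000 nM (range 25000 nM to 200000 nM), an expected step of a 1.1-fold higher number from compound 1 to compound 4 (0.05 log units; within the scatter).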

Compound 4, half-maximal inhibitory concentration: 56200 nM
The estimate for compound 4 lay 1.2-fold (0.10 log units) above the measured number; the range from low to high includes it.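

In this assay, for the compounds shown here, a group of 8 heavy atoms in place of a group of 7 heavy atoms, on a saturated chain carbon bound to an oxygen, gives a 1.1-fold lower number from compound 1 to compound 4 (0.05 log units; within the scatter), the only measured step that touches this chain. The chain therefore takes this change without a readable shift in either direction. Compound 2 and compound 3 remain at a limit, which is not a number: the limit of > 100000 nM in this assay, at which 2 of the 4 values shown sit. Going by these compounds, what a longer chain, or an amine or carboxylic acid on this chain, would do remains open.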